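Ethyl on the ring oxygen: a shift seen once, expected again

A few compounds are considered here, and "the series" means these few. Any claim that something is new, unique, unknown or untested is made for them only; others in the source may bear on it.

Three quinone-like compounds have been measured in a functional assay on DU-145 cells (Homo sapiens) for cytotoxicity, read by XTT assay, with a stated time of 24 h; on this read-out higher numbers stand for weaker inhibition and lower numbers for stronger inhibition. Compound 1 `Cc1cc(Cl)c2c(c1O)C(=O)C=CC2=O` gives 9300 nM, while compound 2 `Cc1cc(O)c2c(c1Cl)C(=O)C=CC2=O` gives 29500 nM; these two share the same atoms joined differently, and the difference between the two cores is not broken down here. Compound 3 `CCOc1c(C)cc(Cl)c2c1C(=O)C=CC2=O` gives 26200 nM. Compound 3 arises from compound 1 by the change (ethyl in place of hydrogen on an oxygen on an aromatic ring), and that step is a 2.8-fold higher number from compound 1 to compound 3 (0.45 log units; beyond the scatter). The unmeasured compound 4 `CCOc1cc(C)c(Cl)c2c1C(=O)C=CC2=O` arises from compound 2 by the same change, (ethyl in place of hydrogen on an oxygen on an aromatic ring). Among the compounds with values here, because the only comparable step is a 2.8-fold higher number from compound 1 to compound 3 (0.45 log units; beyond the scatter), a weakening of similar size is expected from compound 2 to compound 4, namely a 2.5-fold higher number from compound 2 to compound 4 (0.41 log units; beyond the scatter). Compound 4 is therefore estimated at 75000 nM, expected to fall between 25000 nM and 200000 nM, resting on one prior step only.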

Compound 4, half-maximal inhibitory concentration: 25400 nM
Compound 4: middle estimate off by 3.0-fold (0.47 log units), on the high side; the measured number falls inside the stated range.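

On the core of compound 2, replacing hydroxy with ethoxy in this assay gives a 1.2-fold lower number from compound 2 to compound 4 (0.06 log units; within the scatter), so the weakening seen on the core of compound 1 does not appear on this core. The same change therefore did not carry over from one core to the other: the same change on two cores in this assay, a 2.8-fold higher number (0.45 log units; beyond the scatter) from compound 1 to compound 3 and a 1.2-fold lower number (0.06 log units; within the scatter) from compound 2 to compound 4, 3.3-fold (0.51 log units) apart, beyond the scatter of two such steps. This shows that, for these two pairs, the step read on one core did not predict the step on the other, but two pairs do not show why they differ or how the change would behave on any further core.

The compounds shown leave open what a longer chain such as butyl on that oxygen would do. They also leave open whether an amine in place of the ethoxy would separate the two cores in the same way.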